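The source may hold more compounds than are shown below. What is called first, only, known or untested is meant among the compounds shown, and "the series" means these compounds.

In a functional assay on HepG2 cells (Homo sapiens), read by MTT assay, with a stated time of 48 h (on this read-out higher numbers stand for weaker inhibition and lower numbers for stronger inhibition), three compounds sharing one core have been measured. Compound 1 `CCn1c(C(=O)NCC(OC)OC)ccc1C(CC)(CC)c1ccc(OCC(O)C(C)(C)C)c(C)c1` gives 23200 nM. Compound 2 `C#CC(C)OC(=O)c1ccc(C(CC)(CC)c2ccc(OCC(O)C(C)(C)C)c(C)c2)n1CC` gives > 50000 nM, which is a limit of the assay and not a number. Compound 3 `CC[C@@H](C)[C@H](NC(=O)c1ccc(C(CC)(CC)c2ccc(OCC(O)C(C)(C)C)c(C)c2)n1CC)C(=O)O` gives 127 nM, the lowest number of the series. The two steps that reach it are both large: a 180-fold lower number from compound 1 to compound 3 (2.26 log units; beyond the scatter) and an at least 390-fold lower number from compound 2 to compound 3 (2.59 log units; beyond the scatter).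

Compound 4 `CCn1c(C(=O)N(C)CC(=O)O)ccc1C(CC)(CC)c1ccc(OCC(O)C(C)(C)C)c(C)c1` changes compound 3 on a carbonyl carbon: (carboxymethyl)(methyl)amino in place of (1-carboxy-2-methylbutyl)amino on a carbonyl carbon. Here (carboxymethyl)(methyl)amino stands in place of (1-carboxy-2-methylbutyl)amino. Those two large steps bear most directly on this change, since each brought in the group that now leaves. Compound 4 still carries a carboxy group, which compound 1 at 23200 nM lacks, so a full return to that level is not expected. A clear but smaller move toward weaker inhibition in this assay is expected instead. The estimated step is a 12-fold higher number from compound 3 to compound 4 (1.07 log units; beyond the scatter). For compound 4 the estimated value is 1500 nM, with an expected range from 170 nM to 14000 nM.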

Compound 4, half-maximal inhibitory concentration: 17100 nM
For compound 4 the middle estimate is 11-fold (1.06 log units) below the measured one; measured number above the stated range.
By their numbers in this assay, from the lowest: compound 3; then compounds 4 and 1 (each within the scatter of the next). At a limit, above all of these: compound 2.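

The carboxy group by itself does not account for the low number of compound 3 in this assay. Replacing (1-carboxy-2-methylbutyl)amino with (carboxymethyl)(methyl)amino on this carbonyl carbon gives a 130-fold higher number from compound 3 to compound 4 (2.13 log units; beyond the scatter), and although compound 4 keeps a carboxy group, it cannot be told apart from compound 1, which has none: a 1.4-fold lower number from compound 1 to compound 4 (0.13 log units; within the scatter). Compound 4 still differs clearly from compound 2, an at least 2.9-fold lower number from compound 2 to compound 4 (0.46 log units; beyond the scatter), though that step starts from a limit and not a number, the one held by compound 2: the limit of > 50000 nM in this assay, at which 1 of the 4 values shown sits.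

The step from compound 3 to compound 4 removes the carbon chain and adds a methyl on the amide nitrogen at once, and the compounds shown do not separate the two. A (carboxymethyl)amino group, which keeps the amide hydrogen and lacks that chain, would tell them apart.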